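Chain variation on the fluorinated core: compound 4

The compounds below may be only part of what the source reports. "The series", "measured", "known", "first", "only" and "open" are said of these compounds alone.

Among the measured compounds shown here, compound 3 `COc1cc(Cc2nc3c(N)nc(F)nc3n2CCOC(C)C)cc(OC)c1OC` gives 769000000 nM in a functional assay on MCF7 cells (Homo sapiens) for cytotoxicity (a higher number here means that more compound is needed for the effect, a lower number that less compound is needed), the highest number of the three measured so far. Compound 1 `COCCCn1c(Cc2cc(OC)c(OC)c(OC)c2)nc2c(N)nc(F)nc21` gives 72600000 nM and compound 2 `CC[C@H](C)Cn1c(Cc2cc(OC)c(OC)c(OC)c2)nc2c(N)nc(F)nc21` gives 66700000 nM; the steps of an 11-fold higher number from compound 1 to compound 3 (1.02 log units; beyond the scatter) and a 12-fold higher number from compound 2 to compound 3 (1.06 log units; beyond the scatter) are both large, whereas a 1.1-fold lower number from compound 1 to compound 2 (0.04 log units; within the scatter) stays within the scatter. Compound 4 `C#CCCn1c(Cc2cc(OC)c(OC)c(OC)c2)nc2c(N)nc(F)nc21` carries ethynyl in place of isopropoxy on a saturated chain carbon, two bonds along the chain from an aromatic nitrogen. This change removes the isopropoxy group that separates compound 3 from compound 1 and compound 2, so both large steps bear on it; those two chains without that group sit close together whether or not an ether oxygen remains. Compound 4 is therefore expected to fall back toward them, a step of a 9.6-fold lower number from compound 3 to compound 4 (0.98 log units; beyond the scatter). The estimate for compound 4 is 80000000 nM, with a range from 30000000 nM to 250000000 nM.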

Compound 4, half-maximal effective concentration: 286000000 nM
Compound 4: the middle estimate sits 3.6-fold (0.55 log units) below what was measured; the measured number lies above the stated range.
By their numbers in this assay, from the lowest: compounds 2 and 1 (each within the scatter of the next); then compound 4; then compound 3.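

In this assay the but-3-yn-1-yl chain of compound 4 does not group with the chains of compound 1 and compound 2, as shown by a 3.9-fold higher number from compound 1 to compound 4 (0.60 log units; beyond the scatter) and a 4.3-fold higher number from compound 2 to compound 4 (0.63 log units; beyond the scatter). Removing isopropoxy at this position therefore closes only part of the gap, with a 2.7-fold lower number from compound 3 to compound 4 (0.43 log units; beyond the scatter), and compound 4 stands apart from all three neighbours. No supporting measurement bears on this ordering. Still open, going by these compounds, is how a longer chain ending in ethynyl would read at this position. A terminal amine on the chain is equally unresolved.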